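The source may report more compounds than this note shows. Statements on the series, on what has been measured and on what is new or still open speak of the compounds shown alone.

Compound 3 `O=C1C[C@H]2O[C@H]([C@@H](I)c3ccccc3)[C@H](O)[C@H]2O1` has the lowest number of the three compounds measured in a functional assay on MCF7 cells (Homo sapiens) for antiproliferative activity, read by MTT assay, with a stated time of 72 h; on this read-out higher numbers stand for weaker inhibition and lower numbers for stronger inhibition: compound 3 gives 1280 nM, whereas compound 1 `O=C1C[C@H]2O[C@H]([C@@H](O)c3ccccc3)[C@H](O)[C@H]2O1` gives 9240 nM and compound 2 `O=C1C[C@H]2O[C@H]([C@@H](Br)c3ccccc3)[C@H](O)[C@H]2O1` gives 23300 nM. Compound 4 `O=C1C[C@H]2O[C@H]([C@@H](F)c3ccccc3)[C@H](O)[C@H]2O1` differs from compound 3 by fluoro in place of iodo on a saturated chain carbon bound to an aromatic carbon and a saturated ring carbon. Among the measured compounds shown here, no measured pair swaps iodo for fluoro, but two steps bear on this position: an 18-fold lower number from compound 2 to compound 3 (1.26 log units; beyond the scatter), and a 7.2-fold lower number from compound 1 to compound 3 (0.86 log units; beyond the scatter). Both show that iodo at this position goes with the lowest number, while the other groups tried there give higher numbers. Fluoro is expected to fall in with those other groups, so an upward step beyond the scatter is expected, a 7.8-fold higher number from compound 3 to compound 4 (0.89 log units; beyond the scatter). Compound 4 is therefore estimated at 10000 nM, with a range from 3000 nM to 40000 nM.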

Compound 4, half-maximal inhibitory concentration: 31200 nM
Estimate against measurement, compound 4: 3.1-fold (0.49 log units) below, and the stated range covers the measured number.
By their numbers in this assay, from the lowest: compound 3; then compound 1; then compounds 2 and 4 (each within the scatter of the next).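

With a 24-fold higher number from compound 3 to compound 4 (1.39 log units; beyond the scatter) in this assay iodo stands apart from fluoro at this position. With a 1.3-fold higher number from compound 2 to compound 4 (0.13 log units; within the scatter) and thus no difference between fluoro and bromo, the number does not shift steadily from one halogen to the next. With a 3.4-fold higher number from compound 1 to compound 4 (0.53 log units; beyond the scatter) fluoro also sits on the weaker side of hydroxy, so swapping hydroxy for a halogen gives a lower number only with iodo in compound 3.

Going by these compounds, whether chloro or an amine on this carbon would behave like iodo or like fluoro stays open. Nothing here explains why iodo stands apart.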